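A Methylpyridine Replaces a Halogenated Ring

The compounds below may be only part of what the source reports. "The series", "measured", "known", "first", "only" and "open" are said of these compounds alone.

Going by the values given here, compound 3 `CC[C@@H](Nc1c(C#N)c(-c2ccc(-c3cccc(Cl)c3F)cc2)nc2cnccc12)C(N)=O` gives 3.1 in a physicochemical assay for lipophilicity, read by HPLC, at pH 7.5 (a lower number here means a more polar compound, a higher number a more lipophilic compound), the highest of the three numbers measured so far. Compound 2 `CC[C@@H](Nc1c(C#N)c(-c2ccc(-c3ccc(F)cc3)cc2)nc2cnccc12)C(N)=O` gives 2.7 and compound 1 `CC[C@@H](Nc1c(C#N)c(-c2ccc(-c3ccccc3NC)cc2)nc2cnccc12)C(N)=O` gives 2.5; both lie beyond the scatter from compound 3, as a number 0.40 log units higher from compound 2 to compound 3 (beyond the scatter) and a number 0.60 log units higher from compound 1 to compound 3 (beyond the scatter) show. The remaining step, a number 0.20 log units higher from compound 1 to compound 2 (within the scatter), stays within the scatter.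

Compound 4 `CC[C@@H](Nc1c(C#N)c(-c2ccc(-c3ccncc3C)cc2)nc2cnccc12)C(N)=O` has not yet been measured. It differs from compound 3 in a single place: 3-methylpyridin-4-yl in place of 3-chloro-2-fluorophenyl on an aromatic carbon. The ring that leaves carries two halogens and no hetero atom; the ring that enters carries a methyl group and a nitrogen within the ring, counted as one hydrogen-bond acceptor.

Among the compounds with values here, none of the measured steps swaps a ring of carbon only for a ring with a hetero atom, so direct evidence is missing. The two steps that reach compound 3, a number 0.60 log units higher from compound 1 to compound 3 (beyond the scatter) and a number 0.40 log units higher from compound 2 to compound 3 (beyond the scatter), both run upward, and reversing that kind of change points downward. Compound 4 is expected to give 1.9, within a range from 1.4 to 2.4. The estimated step, a number 1.20 log units lower from compound 3 to compound 4 (beyond the scatter), would be larger than any measured step here.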

Compound 4, distribution coefficient: 2
For compound 4 the middle estimate is 0.10 log units below the measured one, and the stated range covers the measured number.
By their numbers in this assay, from the lowest: compound 4; then compounds 1 and 2 (each within the scatter of the next); then compound 3.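

At this position, on an aromatic carbon para to a large group, all the earlier groups were six-membered aromatic rings of carbon only, and the first ring with a hetero atom, 3-methylpyridin-4-yl, gives the lowest number of the four compounds in this assay, with all three new steps beyond the scatter: a number 1.10 log units lower from compound 3 to compound 4 (beyond the scatter), a number 0.70 log units lower from compound 2 to compound 4 (beyond the scatter) and a number 0.50 log units lower from compound 1 to compound 4 (beyond the scatter). The widest step among the carbon-only rings was a number 0.60 log units higher from compound 1 to compound 3 (beyond the scatter), so this single compound shows that the position can carry a wider spread than those rings alone revealed. Nothing shown gives a reason for this drop.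

From the compounds shown here alone, how much of the step belongs to the ring nitrogen and how much to the methyl group stays open, and a plain pyridin-4-yl ring or a 2-methylphenyl ring would help to separate the two. Also open, going by these compounds, is how this position would read with a pyrimidine ring, or with an amine or a carboxylic acid on the ring.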